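Trading a methoxyphenyl for a difluorophenyl at the carbonyl

The compounds below may be only part of what the source reports. "The series", "measured", "known", "first", "only" and "open" are said of these compounds alone.

Compound 1, `COc1ccc(C(=O)/C=C/c2cc(-c3cc(OC)c(OC)c(OC)c3)n[nH]2)cc1OC`, gives 1690 nM in a functional assay on NCI-H226 cells (Homo sapiens) for inhibition, read by sulforhodamine B assay, with a stated time of 48 h; a higher number here means a weaker inhibitor of growth, a lower number a stronger inhibitor of growth.
Compound 2, `COc1ccc(C(=O)/C=C/c2cc(-c3cc(OC)c(OC)c(OC)c3)n[nH]2)cc1`, gives 1890 nM in this assay.

Compound 2 sits alongside compound 1 in this assay; the step of a 1.1-fold higher number from compound 1 to compound 2 (0.05 log units; within the scatter) lies within the scatter, so the two cannot be told apart. Compound 3, `COc1cc(-c2cc(/C=C/C(=O)c3ccc(F)c(F)c3)[nH]n2)cc(OC)c1OC`, differs from compound 2 by 3,4-difluorophenyl in place of 4-methoxyphenyl on a carbonyl carbon. For the measured compounds named here, the only measured step, a 1.1-fold higher number from compound 1 to compound 2 (0.05 log units; within the scatter), also altered this same ring and moved the number very little, but it removed a methoxy rather than exchanging the whole ring for one carrying fluorine, so it bears only loosely on the new change. Going by the values given here, no measured pair shows what fluorine does here. The step of a 1.2-fold higher number from compound 2 to compound 3 (0.07 log units; within the scatter) is therefore expected to stay close to the scatter, with wide uncertainty in either direction. For compound 3 the estimate in this assay is 2200 nM, within a range from 700 nM to 7000 nM.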

Compound 3, concentration for 50% growth inhibition: 3720 nM
Compound 3: middle estimate off by 1.7-fold (0.23 log units), on the low side, and the stated range covers the measured number.
By their numbers in this assay, from the lowest: compounds 1, 2 and 3 (each within the scatter of the next, the first and the last beyond it).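

In this assay, for the compounds shown here, 3,4-difluorophenyl on the carbonyl carbon gives the first step at this position that leaves the scatter, a 2.2-fold higher number from compound 1 to compound 3 (0.34 log units; beyond the scatter), a modest loss of growth inhibition measured against the 3,4-dimethoxyphenyl ring. Measured against the 4-methoxyphenyl ring, the same ring gives a 2.0-fold higher number from compound 2 to compound 3 (0.29 log units; within the scatter), so that exchange cannot be told from no change, and a ring with no methoxy at all still gives a number in the same general range. Nothing measured here offers a reason for these numbers.

The numbers do not settle whether the shift goes with gaining fluorine or with losing methoxy. An unsubstituted phenyl or a 4-fluorophenyl on this carbonyl carbon would help separate the two, while a ring carrying an amine or a carboxylic acid remains an open question.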